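A Larger Pyrimidine on the Sulfonamide Nitrogen

A few compounds are considered here, and "the series" means these few. Any claim that something is new, unique, unknown or untested is made for them only; others in the source may bear on it.

Among the compounds with values here, of the two numbers known in a functional assay on AS49-RAW cells (Homo sapiens) for antiproliferative activity, read by sulforhodamine B assay, with a stated time of 48 h (on this read-out higher numbers stand for weaker inhibition and lower numbers for stronger inhibition), compound 2 `Cc1ccnc(NS(=O)(=O)c2ccc(N/C(S)=N\c3ccnc4cc(C(F)(F)F)ccc34)cc2)n1` gives 31000 nM and compound 1 `N=C(N)NS(=O)(=O)c1ccc(N/C(S)=N\c2ccnc3cc(C(F)(F)F)ccc23)cc1` gives 23900 nM; the one measured step, a 1.3-fold higher number from compound 1 to compound 2 (0.11 log units; within the scatter), lies within the scatter. Compound 3 `COc1ncnc(NS(=O)(=O)c2ccc(N/C(S)=N\c3ccnc4cc(C(F)(F)F)ccc34)cc2)c1OC` carries 5,6-dimethoxypyrimidin-4-yl in place of 4-methylpyrimidin-2-yl on a sulfonamide nitrogen. That single step bears directly on this change, since it also swapped the substituent on the sulfonamide nitrogen, and it moved the number little, so no shift beyond the scatter is expected here. The expected step is a 1.0-fold lower number from compound 2 to compound 3 (0.01 log units; within the scatter). Compound 3 is therefore estimated at 30000 nM, within a range of 12000 nM to 75000 nM.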

Compound 3, half-maximal inhibitory concentration: 81800 nM
Estimate against measurement, compound 3: 2.7-fold (0.44 log units) below; measured number above the stated range.
By their numbers in this assay, from the lowest: compounds 1 and 2 (each within the scatter of the next); then compound 3.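

In this assay, the group on the sulfonamide nitrogen now moves the number beyond the scatter: 5,6-dimethoxypyrimidin-4-yl in place of 4-methylpyrimidin-2-yl gives (a 2.6-fold higher number from compound 2 to compound 3 (0.42 log units; beyond the scatter)), and the same group in place of the smaller one in compound 1 gives (a 3.4-fold higher number from compound 1 to compound 3 (0.53 log units; beyond the scatter)). So this position does not tolerate every pyrimidine equally, and compound 3 is the weakest inhibitor of the three. Nothing measured here explains the shift.

The compounds shown leave open whether the rise follows the two methoxy groups or the change of pyrimidine attachment. They also leave open how a pyrimidine bearing an amine or a carboxylic acid would read.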